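The compounds below may be only part of what the source reports. "The series", "measured", "known", "first", "only" and "open" are said of these compounds alone.

For the measured compounds named here, compound 1 `O=C(CCc1ccc(C(F)(F)F)cc1)Nc1ccc2nc(N3CCC(c4ccccc4)C3)ccc2c1` stands highest of the two numbers measured so far in a functional assay on HEK293 cells for activation of melanin-concentrating hormone receptor 1 (Rattus norvegicus), read by inositol phosphate accumulation; a higher number here means that more compound is needed for the effect, a lower number that less compound is needed: compound 1 gives 1770 nM, whereas compound 2 `O=C(CCCCCCCCCCCCc1ccc(C(F)(F)F)cc1)Nc1ccc2nc([N+]34CCC(CC3)CC4)ccc2c1` gives 25 nM, a gap beyond the usual scatter. Compound 3 `CNC(=O)NC1CCN(c2ccc3cc(NC(=O)CCc4ccc(C(F)(F)F)cc4)ccc3n2)C1` has not yet been measured; it differs from compound 1 in one place ((methylcarbamoyl)amino in place of phenyl on a saturated ring carbon). Going by the values given here, no measured pair shows this change, so the expectation rests on compound 1 alone and is uncertain. A modest step towards a higher number, possibly beyond the scatter, is expected, meaning a 2.0-fold higher number from compound 1 to compound 3 (0.30 log units; within the scatter) from compound 1. Compound 3 is therefore estimated at 3500 nM, ranging from 800 nM to 15000 nM.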

Compound 3, half-maximal effective concentration: 30 nM
Compound 3: the middle estimate sits 120-fold (2.07 log units) above what was measured; the measured number lies below the stated range.
By their numbers in this assay, from the lowest: compounds 2 and 3 (each within the scatter of the next); then compound 1.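

On the saturated ring carbon two ring bonds from the ring nitrogen, the phenyl of compound 1 proves dispensable in this assay: placing (methylcarbamoyl)amino there gives a 59-fold lower number from compound 1 to compound 3 (1.77 log units; beyond the scatter). This position therefore accepts a group with no ring and with hydrogen-bond donors, and the number responds strongly to what sits on it. Nothing measured here accounts for this large step. As far as these compounds go, whether a plain amine or an acetylamino group on this ring carbon would give a number like that of compound 3 remains open.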